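Replacing the 4-(1H-imidazol-1-yl)butyl group of compound 2

The source may report more compounds than this note shows. Statements on the series, on what has been measured and on what is new or still open speak of the compounds shown alone.

Three compounds sharing one core have numbers in a functional assay on A-375 cells (Homo sapiens) for cytotoxicity, read by MTT assay, with a stated time of 72 h; a higher number here means a weaker inhibitor, a lower number a stronger inhibitor. Compound 1 `O=C1c2c[n+]([O-])c3ccccc3c2C(=O)c2c1c1ccccc1n2Cc1cn([C@H]2O[C@H](CO)[C@@H](O)[C@H]2O)nn1` gives 340 nM and compound 2 `O=C1c2c[n+]([O-])c3ccccc3c2C(=O)c2c1c1ccccc1n2CCCCn1ccnc1` gives 350 nM, so these two lie level, within the scatter of each other. Compound 3 `CN1CCN(CCCCn2c3c(c4ccccc42)C(=O)c2c[n+]([O-])c4ccccc4c2C3=O)CC1` gives 30 nM. Compound 2 thus shares the upper end of this small range with compound 1.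

Compound 4 `O=C1c2c[n+]([O-])c3ccccc3c2C(=O)c2c1c1ccccc1n2CCN1CCCC1` has not yet been measured. Its difference from compound 2 is this: pyrrolidin-1-yl in place of 2-(1H-imidazol-1-yl)ethyl on a saturated chain carbon, two bonds along the chain from an aromatic nitrogen. In words, pyrrolidin-1-yl stands in place of 2-(1H-imidazol-1-yl)ethyl on a saturated chain carbon, two bonds along the chain from an aromatic nitrogen.

Going by the values given here, one measured step bears on this change: a 12-fold lower number from compound 2 to compound 3 (1.07 log units; beyond the scatter), a large move beyond the scatter, in which 4-methylpiperazin-1-yl replaced 1H-imidazol-1-yl. Among the compounds with values here, compound 4 also gives up the five-membered aromatic ring for a non-aromatic ring, but it carries a 2-(pyrrolidin-1-yl)ethyl group, and no measured step isolates that difference in the chain. Only part of the large step is therefore expected to carry over, in the same direction. The estimated change is a 4.4-fold lower number from compound 2 to compound 4 (0.64 log units; beyond the scatter). For compound 4 the expected value is 80 nM, with an estimated range from 25 nM to 250 nM.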

Compound 4, half-maximal inhibitory concentration: 430 nM
Beside the measured number, compound 4's estimate is 5.4-fold (0.73 log units) below it, outside the stated range (above it).
By their numbers in this assay, from the lowest: compound 3; then compounds 1, 2 and 4 (each within the scatter of the next).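

In this assay, the move to the 2-(pyrrolidin-1-yl)ethyl group is a 1.2-fold higher number from compound 2 to compound 4 (0.09 log units; within the scatter), so a non-aromatic ring in place of the five-membered aromatic ring does not, in this pair, bring anything like a 12-fold lower number from compound 2 to compound 3 (1.07 log units; beyond the scatter), the step seen with the 4-methylpiperazin-1-yl group. The other new step, a 14-fold higher number from compound 3 to compound 4 (1.16 log units; beyond the scatter), is large and shows that the low number of compound 3 does not extend to every non-aromatic amine ring on a chain at this position, although ring and chain length change together in this step. Nothing given here accounts for the difference between these steps.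

The compounds shown leave open whether the chain length or the ring itself sets this gap, a question that a 4-(pyrrolidin-1-yl)butyl group on the shared core, or the 4-methylpiperazin-1-yl ring on the shorter ethyl chain, would separate. On these data alone, it also remains open how a morpholine ring or an open-chain dimethylamino group at the end of the butyl chain would compare with the 4-methylpiperazin-1-yl group.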